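Trimethoxyphenyl benzimidazoles: a methoxyphenyl variant in view

A few compounds are considered here, and "the series" means these few. Any claim that something is new, unique, unknown or untested is made for them only; others in the source may bear on it.

Compound 1 `COc1cc(-n2cnc3ccc(-c4ccc([N+](=O)[O-])cc4)cc32)cc(OC)c1OC`: 79 nM
Compound 2 `COc1cc(-n2cnc3ccc(-c4cccc(F)c4)cc32)cc(OC)c1OC`: 2490 nM
Compound 3 `COc1cc(-n2cnc3ccc(-c4ccc(Cl)cc4)cc32)cc(OC)c1OC`: 1270 nM

In a functional assay on SGC-7901 cells (Homo sapiens) for antiproliferative activity, read by MTT assay, with a stated time of 72 h (on this read-out lower numbers stand for stronger inhibition and higher numbers for weaker inhibition), compound 3 gives 1270 nM, which places it second highest of the three numbers shown. Its nearest neighbour is compound 2, and the change a 2.0-fold lower number from compound 2 to compound 3 (0.29 log units; within the scatter) stays within the scatter. Its furthest neighbour is compound 1, since a 16-fold higher number from compound 1 to compound 3 (1.21 log units; beyond the scatter) is large. The step from compound 1 to compound 2 is also large, a 32-fold higher number from compound 1 to compound 2 (1.50 log units; beyond the scatter).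

Compound 4 `COc1cccc(-c2ccc3ncn(-c4cc(OC)c(OC)c(OC)c4)c3c2)c1` is not yet measured in this assay. It differs from compound 3 at one position: 3-methoxyphenyl in place of 4-chlorophenyl on an aromatic carbon.

Of the measured steps, the one that bears most on this change is the swap between compound 2 and compound 3, where a 3-fluorophenyl and a 4-chlorophenyl at the same aromatic carbon gave numbers within the scatter. The large steps from compound 1 concern the loss of the nitro group, which compound 3 has already lost. Among the measured compounds shown here, no measured compound carries a methoxyphenyl at this position, so the weight of the evidence is that halogen-to-halogen exchange here moved little, while compound 4 introduces a different kind of group. Compound 4 is therefore expected to land near compound 3, with a step of a 1.2-fold higher number from compound 3 to compound 4 (0.07 log units; within the scatter), with no move beyond the scatter in this assay anticipated. The estimate for compound 4 is 1500 nM, with a range from 500 nM to 5000 nM.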

Compound 4, half-maximal inhibitory concentration: 3310 nM
For compound 4 the middle estimate is 2.2-fold (0.34 log units) below the measured one, and the stated range covers the measured number.
By their numbers in this assay, from the lowest: compound 1; then compounds 3, 2 and 4 (each within the scatter of the next, the first and the last beyond it).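

In this assay, the 3-methoxyphenyl group gives no return towards compound 1, with a 42-fold higher number from compound 1 to compound 4 (1.62 log units; beyond the scatter), so an oxygen-bearing substituent on this phenyl ring does not by itself stand in for the 4-nitrophenyl group of the most potent compound shown. The new result also separates two replacements that could not be told apart before: a 2.6-fold higher number from compound 3 to compound 4 (0.42 log units; beyond the scatter) is modest but passes the scatter, whereas a 1.3-fold higher number from compound 2 to compound 4 (0.12 log units; within the scatter) does not, and the methoxy and fluoro compounds, both carrying their group at the 3-position of the phenyl ring, therefore read alike, while compound 3 stays within the scatter of compound 2 yet not of compound 4. Nothing shown gives a measured reason for any of these steps.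

In the step to compound 4, the substituent and its place on the phenyl ring change together, so the compounds shown leave open which of the two accounts for the modest shift. On these data alone, it also remains open whether a phenyl ring bearing an amine or a nitrile would approach compound 1, at 79 nM, or stay with the other three compounds.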